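The source may hold more compounds than are shown below. What is called first, only, known or untested is meant among the compounds shown, and "the series" means these compounds.

Compound 1 `Cc1ccc2nc(C(=O)Nc3c(F)cc(-c4cccc(F)c4)cc3F)c(C)c(O)c2c1` gives 3.04% in a functional assay on A-375 cells (Homo sapiens) for antiproliferative activity, read by MTT assay, with a stated time of 24 h, tested at 1.23 ug/mL; a lower number here means a weaker effect, a higher number a stronger effect of the compound at the concentration tested. Among the measured compounds shown here, compound 2 `CCc1ccc2nc(C(=O)Nc3c(F)cc(-c4cccc(F)c4)cc3F)c(C)c(O)c2c1` gives 12.3% in this assay and so stands highest of the two numbers so far, a standing the scatter does not separate from compound 1, since the step was a number 9.3 percentage points higher from compound 1 to compound 2 (within the scatter). Compound 3 `Cc1c(C(=O)Nc2c(F)cc(-c3cccc(F)c3)cc2F)nc2ccc(F)cc2c1O` is the next compound to be measured in this assay. Its change from compound 2 is fluoro in place of ethyl on an aromatic carbon. For the measured compounds named here, the only measured step also alters a substituent of the shared core, methyl in place of hydrogen on a saturated chain carbon bound to an aromatic carbon, and it gave a number 9.3 percentage points higher from compound 1 to compound 2 (within the scatter); no measured step exchanges the ethyl for a halogen, so nothing bears directly on this change. Going by the values given here, with the one available step within the scatter, the step expected for compound 3 is a number 5.3 percentage points lower from compound 2 to compound 3 (within the scatter), with no direction that should rise beyond the scatter. Compound 3 is therefore expected to give about 7% in this assay, estimated between 0% and 20%.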

Compound 3, a percentage reported as inhibition, at one concentration (the size of the read-out at that concentration, not a potency): 2.34%
Compound 3: middle estimate off by 4.7 percentage points, on the high side; the measured number falls inside the stated range.
By their numbers in this assay, from the lowest: compounds 3, 1 and 2 (each within the scatter of the next).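

At this aromatic carbon the series now carries methyl, ethyl and fluoro, and in this assay the exchange of ethyl for fluoro gives a number 10 percentage points lower from compound 2 to compound 3 (within the scatter) while the exchange of methyl for fluoro gives a number 0.7 percentage points lower from compound 1 to compound 3 (within the scatter) and so neither exchange separates fluoro from the alkyl groups. With all three steps at this position inside the scatter, the compounds show no dependence of the read-out on whether a carbon chain or a halogen sits here, and no trend with chain length or group size can be drawn from them. No measurement among those given here accounts for these numbers.

Going by these compounds, whether any group at this position can move the read-out beyond the scatter stays open, for instance an amine, a carboxylic acid or a longer chain such as butyl. On these data alone, the read-out gives the size of the effect at one concentration only, so the effect of all three compounds at any other concentration stays open.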